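The source may hold more compounds than are shown below. What is called first, only, known or untested is meant among the compounds shown, and "the series" means these compounds.

Measured so far:
- compound 1, `CN(C)CCNc1nc(-c2ccc(NC(=O)Nc3ccc(F)cc3)cc2)nc2ccsc12`: in a functional assay on MKN-45 cells (Homo sapiens) for cytotoxicity, read by MTT assay, with a stated time of 72 h (a lower number here means a stronger inhibitor, a higher number a weaker inhibitor), compound 1 gives 330 nM
- compound 2, `CCN(CC)CCCNc1nc(-c2ccc(NC(=O)Nc3ccccc3)cc2)nc2ccsc12`: in this assay compound 2 gives 980 nM

Compound 2 carries the higher of the two numbers; compound 1 sits lower, and the gap between them lies beyond the scatter. Among the compounds with values here, the two differ in two places at once, the amine-bearing chain and the terminal ring, so no single step is read from that pair.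

Compound 3, `CCN(CC)CCCNc1nc(-c2ccc(NC(=O)Nc3ccc(F)cc3)cc2)nc2ccsc12`, keeps the chain of compound 2 and changes only the terminal ring: fluoro in place of hydrogen on an aromatic carbon. It thus shares its chain with compound 2 and its fluorinated ring with compound 1. For a substitution of this kind, one heavy atom added at an aromatic carbon, a modest shift is expected, most likely toward the lower number, since compound 1 with the same fluorinated ring shows 330 nM. The expected step from compound 2 to compound 3 is a 1.6-fold lower number from compound 2 to compound 3 (0.21 log units; within the scatter), small and within or near the scatter. Compound 3 is accordingly estimated at 600 nM in this assay, with a range from 250 nM to 1400 nM.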

Compound 3, half-maximal inhibitory concentration: 470 nM
Beside the measured number, compound 3's estimate is 1.3-fold (0.11 log units) above it; measured number inside the range.
By their numbers in this assay, from the lowest: compounds 1 and 3 (each within the scatter of the next); then compound 2.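

In this assay, the terminal ring now gives a change that can be read alone: fluoro in place of hydrogen on an aromatic carbon, para to a large group, gives a 2.1-fold lower number from compound 2 to compound 3 (0.32 log units; beyond the scatter) as a modest step on the chain shared by compound 2 and compound 3. With the 4-fluorophenyl group held fixed, (diethylamino)methyl in place of dimethylamino on a saturated chain carbon gives a 1.4-fold higher number from compound 1 to compound 3 (0.15 log units; within the scatter) so that, in this assay, the chain change does not separate this pair, and the terminal ring is the only one of the two places where a step clears the scatter. No measurement here bears on why the fluoro step occurs.

The compounds shown leave open whether chloro or methoxy on the same aromatic carbon would move the number in the same direction as fluoro, and whether a morpholine at the end of the chain would stay with the two amine chains seen so far. On these data alone, whether the fluoro step carries over to the dimethylamino chain also stays open, since that chain appears here only with the 4-fluorophenyl group.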